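Replacing the Methyl Carbamate Oxygen with Sulfur

The compounds below may be only part of what the source reports. "The series", "measured", "known", "first", "only" and "open" are said of these compounds alone.

Measured compounds:
- Compound 1 `CC(C)OC(=O)N1CCC(Oc2cccc3c2CCN3c2ccc(S(C)(=O)=O)cc2)CC1`: 70%
- Compound 2 `COC(=O)N1CCC(Oc2ncnc3c2CCN3c2ccc(S(C)(=O)=O)cc2F)CC1`: 119%

Both compounds were tested in a functional assay on CHO-K1 cells with Glucose-dependent insulinotropic receptor (Homo sapiens) as the target, read by a luciferase reporter, with a stated time of 5 h; a higher number here means a larger maximal response, a lower number a smaller maximal response. Compound 1 gives 70%, while compound 2 gives 119%. Of the two numbers, compound 2 stands highest, and its distance from compound 1 lies well beyond the usual scatter of repeated measurements. No single-point comparison between these two exists, since they differ in several places at once, so their values can only be taken as they are.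

Compound 3 `CC(C)SC(=O)N1CCC(Oc2ncnc3c2CCN3c2ccc(S(C)(=O)=O)cc2F)CC1` has not yet been measured. It differs from compound 2 in one place: isopropylsulfanyl in place of methoxy on a carbonyl carbon. The rest of the molecule, including the shared core and the methylsulfonyl-bearing aryl group, is unchanged.

Nothing in the two measured compounds isolates the effect of this exchange. The expectation is therefore a small step in this assay, likely a slight decrease or none beyond the scatter, with compound 3 estimated to give 105%, in a range from 80% to 130%. This corresponds to an expected step of a number 14 percentage points lower from compound 2 to compound 3 (beyond the scatter).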

Compound 3, largest response reached (reported as percent of maximum), in percent of the reference or control that the assay uses: 138%
Compound 3: middle estimate off by 33 percentage points, on the low side; the measured number lies above the stated range.
By their numbers in this assay, from the lowest: compound 1; then compound 2; then compound 3.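

Going by these compounds alone, on the carbonyl carbon whose other neighbour is an amide-type nitrogen in a ring, exchanging methoxy for isopropylsulfanyl gives a number 19 percentage points higher from compound 2 to compound 3 (beyond the scatter) in this assay and so provides the first reading at this position from a change in one place. The position therefore accepts isopropylsulfanyl here without any loss of maximal response, and the response rises instead. This single exchange alters both the atom attached to the carbonyl carbon and the group carried by that atom, and nothing measured here accounts for the rise.

The compounds shown leave open whether the higher response follows the sulfur or the isopropyl part, a question that isopropoxy and methylsulfanyl on the same carbonyl carbon, with the rest of compound 3 kept, could help to separate. From the compounds shown here alone, it also remains open how the response would change with a longer chain such as n-butylsulfanyl, or with an amine such as dimethylamino, at this same place.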